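Swapping the aryl group on the pyrazole nitrogen: compound 4

The source may hold more compounds than are shown below. What is called first, only, known or untested is meant among the compounds shown, and "the series" means these compounds.

Measured so far in an assay on isolated protein for displacement of a labelled ligand from Glucagon receptor (Homo sapiens); on this read-out lower numbers stand for stronger inhibition and higher numbers for weaker inhibition:
- compound 1 `CCCC(Oc1cnn(-c2ccc(C(F)(F)F)cn2)c1)c1ccc(C(=O)NCCC(=O)O)cc1`: 1190 nM
- compound 2 `CCCC(Oc1cnn(-c2ccc(OC)cc2)c1)c1ccc(C(=O)NCCC(=O)O)cc1`: 1980 nM
- compound 3 `CCCC(Oc1cnn(-c2cccc(CC)c2)c1)c1ccc(C(=O)NCCC(=O)O)cc1`: 556 nM

Compound 3 gives the lowest number of the three; its gaps to compound 1 and compound 2 are both beyond the scatter, so it is the strongest binder shown. Compound 4 `CCCC(Oc1cnn(-c2ccccc2C)c1)c1ccc(C(=O)NCCC(=O)O)cc1` carries 2-methylphenyl in place of 3-ethylphenyl on an aromatic nitrogen. Going by the values given here, no measured pair shows this exact swap. The related steps of a 2.1-fold lower number from compound 1 to compound 3 (0.33 log units; beyond the scatter) and a 3.6-fold lower number from compound 2 to compound 3 (0.55 log units; beyond the scatter) show that changing the group on this nitrogen shifts the read-out by modest amounts in either direction. Since compound 3 holds the best group seen so far, a modest loss is expected for compound 4: a 1.7-fold higher number from compound 3 to compound 4 (0.23 log units; within the scatter). Compound 4 is estimated at 950 nM, within 350 nM to 2600 nM.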

Compound 4, inhibition constant: 14700 nM
Estimate against measurement, compound 4: 15-fold (1.19 log units) below; measured number outside the range, above it.
By their numbers in this assay, from the lowest: compound 3; then compounds 1 and 2 (each within the scatter of the next); then compound 4.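

In this assay, this position proves far less forgiving than the earlier compounds suggested. 2-Methylphenyl costs much more binding than any earlier swap changed it, with steps against all three other groups (a 26-fold higher number from compound 3 to compound 4 (1.42 log units; beyond the scatter); a 7.4-fold higher number from compound 2 to compound 4 (0.87 log units; beyond the scatter); a 12-fold higher number from compound 1 to compound 4 (1.09 log units; beyond the scatter)), which makes compound 4 the weakest binder shown. Nothing available here bears on the cause of this loss.

This change moves the substituent on the phenyl ring and also shortens it from ethyl to methyl, so the two effects remain tangled. A 3-methylphenyl or a 2-ethylphenyl group would pull them apart.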